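Trimethoxybenzyl Variant of a Diaminoquinoxaline Growth Inhibitor

The source may report more compounds than this note shows. Statements on the series, on what has been measured and on what is new or still open speak of the compounds shown alone.

Measured compounds:
Compound 1, `CCOC(=O)[C@H](CCC(=O)O)NC(=O)c1ccc(CNc2nc3cc(N)cc(N)c3nc2-c2ccccc2)cc1`: < 100000 nM in a functional assay on HT-29 cells (Homo sapiens) for inhibition, read by sulforhodamine B assay, with a stated time of 48 h; a higher number here means a weaker inhibitor of growth, a lower number a stronger inhibitor of growth; this is a limit of the assay, not a number.
Compound 2, `COc1ccc(CNc2nc3cc(N)cc(N)c3nc2-c2ccccc2)cc1OC`: 24500 nM.
Compound 3, `CCOC(=O)[C@H](CCC(=O)O)NC(=O)c1ccc(Sc2nc3cc(N)cc(N)c3nc2-c2ccccc2)cc1`: < 100000 nM; again a limit, not a number.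

Among these three, compound 2 is the only one with a measured number in this assay; the other two sit at the limit, as noted in the limit of < 100000 nM in this assay, at which 2 of the 3 values shown sit, so no step between measured compounds can be sized.

Compound 4, `COc1cc(CNc2nc3cc(N)cc(N)c3nc2-c2ccccc2)cc(OC)c1OC`, differs from compound 2 by methoxy in place of hydrogen on an aromatic carbon. It sits on the same benzyl ring that already carries the methoxy groups of compound 2, ortho to a methoxy group and meta to a methoxy group and to a large group.

Within the data shown here, with no measured step of this kind to lean on, the change from compound 2 is expected to fall within the usual scatter, with no direction claimed; the estimated step is a 1.2-fold lower number from compound 2 to compound 4 (0.09 log units; within the scatter). Compound 4 is therefore estimated at 20000 nM in this assay, expected to lie between 6000 nM and 70000 nM.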

Compound 4, concentration for total growth inhibition: 19500 nM
The estimate for compound 4 lay 1.0-fold (0.01 log units) above the measured number, within the range that was stated.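

Methoxy in place of hydrogen on this aromatic carbon, ortho to a methoxy group and meta to a large group and to a methoxy group, gives a 1.3-fold lower number from compound 2 to compound 4 (0.10 log units; within the scatter) in this assay. Among these compounds, this is the first step that can be sized here, and it shows that this position takes the added methoxy group with the two values staying within the scatter of each other. No step to compound 1 or compound 3 can be read: the limit of < 100000 nM in this assay, at which 2 of the 4 values shown sit.

The compounds shown leave open whether an amine, a carboxylic acid or a longer chain on this same carbon would give a step beyond the scatter. A single step also cannot show whether methoxy would give a similar result on another carbon of this ring.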